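The compounds below may be only part of what the source reports. "The series", "measured", "known", "first", "only" and "open" are said of these compounds alone.

Compound 3, with the structure `Cc1cccc(NC(=O)c2nnc(COc3ccc(CCC(=O)O)cc3)s2)c1`, carries a methyl group on an aromatic ring at one end and an acid-bearing chain at the other. In a functional assay on CHO cells for agonist activity at Free fatty acid receptor 1 (Homo sapiens), read by calcium flux (a lower number here means that less compound is needed, a higher number that more compound is needed for the effect), compound 3 gives 1770 nM. Two other compounds from the same series have been measured. Compound 1, `O=C(O)CCc1nnc(C(=O)Nc2cccc(-c3ccc(F)cc3)c2)s1`, gives 1280 nM in this assay, a number that lies within the usual scatter of the number for compound 3, so the two cannot be told apart. Compound 2, `O=C(O)CCc1nnc(C(=O)Nc2ccc(OCc3ccccc3)cc2)s1`, gives 17900 nM, a number beyond the scatter and well above that of compound 3. Among these three numbers, that of compound 3 is the second highest.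

Compound 4, `O=C(O)CCc1ccc(OCc2nnc(C(=O)Nc3cccc(Cl)c3)s2)cc1`, has not yet been measured. It differs from compound 3 in one place: chloro in place of methyl on an aromatic carbon, on a six-membered aromatic ring of carbon only. For the measured compounds named here, no measured pair shows this exact exchange, so any expectation must rest on the closeness of the measured numbers and on the modest size of the change. A step no larger than the usual scatter is expected in this assay, in either direction. The step from compound 3 to compound 4 is expected to be a 1.2-fold lower number from compound 3 to compound 4 (0.07 log units; within the scatter). Compound 4 is therefore estimated to give 1500 nM, within a range from 600 nM to 4000 nM.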

Compound 4, half-maximal effective concentration: 10600 nM
Compound 4: middle estimate off by 7.1-fold (0.85 log units), on the low side, and the stated range ends below it.
By their numbers in this assay, from the lowest: compounds 1 and 3 (each within the scatter of the next); then compounds 4 and 2 (each within the scatter of the next).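

Exchanging the methyl of the 3-methylphenyl group for chloro replaces one heavy atom with one heavy atom and changes no ring, hydrogen-bond donor, acceptor or net charge, yet in this assay it gives a 6.0-fold higher number from compound 3 to compound 4 (0.78 log units; beyond the scatter), a modest step but one beyond the scatter. This shows that the aromatic carbon meta to a large group is not indifferent to which single atom it carries, so even an exchange this small can change how much compound is needed for the effect. The earlier compounds could not show this, as no two of them formed a pair differing in one place, and nothing at hand bears on why the number moves.

On these data alone, it remains open whether a hydrogen, fluoro, methoxy or nitrile at this place would give a number nearer that of compound 3 or that of compound 4. Also open, as far as these compounds go, is whether chloro on another carbon of this ring would give a similar number, and whether the same exchange would produce a step of this size on a different core.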